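A few compounds are considered here, and "the series" means these few. Any claim that something is new, unique, unknown or untested is made for them only; others in the source may bear on it.

In a functional assay on CEM-DNR-bulk cells (Homo sapiens), read by MTT assay, with a stated time of 72 h (a lower number here means a stronger inhibitor, a higher number a weaker inhibitor), compound 1 `CN(C)c1ncnc2c1c(-c1ccoc1)cn2[C@@H]1O[C@H](CO)[C@@H](O)[C@H]1O` gives > 20000 nM as a limit of the assay. Compound 2 `Nc1nc(N)c2c(-c3cccs3)cn([C@@H]3O[C@H](CO)[C@@H](O)[C@H]3O)c2n1` gives > 20000 nM as a limit as well. Compound 3 `Cc1nc(N)c2c(-c3cccs3)cn([C@@H]3O[C@H](CO)[C@@H](O)[C@H]3O)c2n1` stands at > 20000 nM and this too is a limit. Among the measured compounds shown here, the series so far shows only the limit of > 20000 nM in this assay, at which 3 of the 3 values shown sit, and no graded value. The change to compound 4 `Cc1nc(N)c2c(I)cn([C@@H]3O[C@H](CO)[C@@H](O)[C@H]3O)c2n1` is iodo in place of thiophen-2-yl on an aromatic carbon with iodo in place of thiophen-2-yl on an aromatic carbon. For the measured compounds named here, the only measured step is a step that the two limits leave unreadable from compound 2 to compound 3 and it concerns a different group, so it offers no size to carry over. No sized step can be expected in this assay and compound 4 is expected to stay near the same limit. For compound 4 the estimate is 15000 nM with an expected range from 5000 nM to 20000 nM overall. The estimated change is an at least 1.3-fold lower number from compound 3 to compound 4 (0.12 log units; that floor lies within the scatter) and it is expected to be small.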

Compound 4, half-maximal inhibitory concentration: 3480 nM
Compound 4: middle estimate off by 4.3-fold (0.63 log units), on the high side; the measured number lies below the stated range.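

Among the compounds shown here, this position is the first place where a change produces a readable response: in this assay, iodo in place of thiophen-2-yl on the aromatic carbon gives an at least 5.7-fold lower number from compound 3 to compound 4 (0.75 log units; beyond the scatter). The step has a limit at one end, as the value of compound 3 is only a limit, and the step from compound 2 to compound 3 cannot be read. Compound 4 is thus the only graded value in the series: the limit of > 20000 nM in this assay, at which 3 of the 4 values shown sit.

On these data alone, whether bromo, chloro or an amine on this carbon would also leave the limit remains open. Also open, as far as these compounds go, is how the iodo compound would respond to amino in place of methyl.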